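Notes on the ether side chain of a pyrazolo-lactam series

A few compounds are considered here, and "the series" means these few. Any claim that something is new, unique, unknown or untested is made for them only; others in the source may bear on it.

Measured compounds:
- compound 1 `Cc1nn(-c2ncnc3nc[nH]c23)c2c1C(OCc1ccc(C#N)cc1)CC(=O)N2`, 60 nM
- compound 2 `COc1ccc(CCOC2CC(=O)Nc3c2c(C)nn3-c2ncnc3nc[nH]c23)cc1`, 70 nM

Both compounds share the same core and differ only in the group on the saturated chain carbon bound to an oxygen on a saturated carbon. In a functional assay on HEK293 cells for agonist activity at G-protein coupled receptor 39 (Homo sapiens), read by scintillation proximity assay and inositol phosphate accumulation, with a stated time of 75 min (on this read-out higher numbers stand for an effect only at larger amounts of compound and lower numbers for an effect already at smaller amounts), compound 1 gives 60 nM, and in this assay compound 2 gives 70 nM. The step of a 1.2-fold higher number from compound 1 to compound 2 (0.07 log units; within the scatter) is within the scatter, so the two numbers are to be read as equivalent; compound 2 stands with compound 1 and not apart from it.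

Compound 3 `Cc1nn(-c2ncnc3nc[nH]c23)c2c1C(OCc1cc(F)cc3c1OCOC3)CC(=O)N2` carries the change (a group of 11 heavy atoms (8 carbon, 2 oxygen, 1 fluorine; one six-membered non-aromatic ring with 2 hetero atoms, one six-membered aromatic ring of carbon only) in place of a group of 9 heavy atoms (8 carbon, 1 oxygen; one six-membered aromatic ring of carbon only), on a saturated chain carbon bound to an oxygen on a saturated carbon). Among the compounds with values here, the only measured step that bears on this position is a 1.2-fold higher number from compound 1 to compound 2 (0.07 log units; within the scatter), which was within the scatter; nothing else at this position has been measured. On that basis a step beyond the scatter is not expected, in either direction, and compound 3 is estimated at 70 nM in this assay (range 25 nM to 200 nM). The step this estimate means, no change at the digits printed from compound 2 to compound 3 (within the scatter), is expected to stay within the scatter.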

Compound 3, half-maximal effective concentration: 30 nM
The estimate for compound 3 lay 2.3-fold (0.37 log units) above the measured number; the range from low to high includes it.
By their numbers in this assay, from the lowest: compounds 3, 1 and 2 (each within the scatter of the next, the first and the last beyond it).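

In this assay this position, on a saturated chain carbon bound to an oxygen on a saturated carbon, now gives its first step beyond the scatter: a 2.3-fold lower number from compound 2 to compound 3 (0.37 log units; beyond the scatter) is modest, but it shows that the number can respond to the group placed here. Against compound 1 the same group gives a 2.0-fold lower number from compound 1 to compound 3 (0.30 log units; within the scatter) and this stays within the scatter, so compound 3 separates from compound 2 only and cannot be ranked apart from compound 1. The position also accepts a group of 11 heavy atoms with a six-membered non-aromatic ring holding 2 hetero atoms without any loss in this read-out, and no measurement at hand bears on the cause of the step.

On these data alone, the fluorine and the non-aromatic ring enter together in compound 3, so their separate shares in the step remain open. Also open, as far as these compounds go, is how this position responds to a group of a different kind, such as an amine, a carboxylic acid or a longer chain.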